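Swapping chloro for hydroxy at a sensitive aromatic position

The source may hold more compounds than are shown below. What is called first, only, known or untested is meant among the compounds shown, and "the series" means these compounds.

In an ADME assay on HT-29 cells (Homo sapiens) for cytotoxicity, read by MTT assay, with a stated time of 72 h (on this read-out higher numbers stand for weaker inhibition and lower numbers for stronger inhibition), compound 2 (`COc1ccc(C2=C(c3cc(OC)c(OC)c(OC)c3)C(=O)C(OC(C)=O)C2)cc1Cl`) gives < 1 ug/mL, which is a limit of the assay and not a number. Its close relative compound 1 (`COc1ccc(C2=C(c3cc(OC)c(OC)c(OC)c3)C(=O)C(OC(C)=O)C2)cc1OC(C)C`) gives > 100 ug/mL, which is also a limit. Putting chloro in place of isopropoxy on the aromatic carbon produces an at least 100-fold lower number from compound 1 to compound 2 (2.00 log units; beyond the scatter), so the group at this position clearly matters in these two compounds.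

Compound 3 (`COc1ccc(C2=C(c3cc(OC)c(OC)c(OC)c3)C(=O)C(OC(C)=O)C2)cc1O`) changes that same position again, with hydroxy in place of chloro on an aromatic carbon. For the measured compounds named here, only one measured step bears on this change, and it involves a different pair of groups, so it gives guidance but no direct answer. Hydroxy, like chloro, is a single heavy atom, whereas the large loss in compound 1 came with isopropoxy, as an at least 100-fold lower number from compound 1 to compound 2 (2.00 log units; beyond the scatter) shows. Compound 3 is therefore expected to stay much nearer compound 2, with no large step in either direction. The expected change is a step that the limit leaves unreadable from compound 2 to compound 3. For compound 3 the estimated value is 0.6 ug/mL, with an expected range from 0.08 ug/mL to 5 ug/mL.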

Compound 3, half-maximal inhibitory concentration: < 1 ug/mL
Compound 3 ended at the assay's limit; the forecaster's own chance of this, stated with the estimate: 55%; the middle value is on the limit's open side.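

In this assay, taking the isopropyl off the oxygen gives an at least 100-fold lower number from compound 1 to compound 3 (2.00 log units; beyond the scatter), so the large gap to the isopropoxy compound is not special to chloro: a second group with a single heavy atom also lands on the strong side of the assay's range. Chloro and hydroxy cannot be ranked against each other, and the step between them cannot be read, because both compounds sit at the same assay limit, which is a boundary and not a number: the limit of < 1 ug/mL in this assay, at which 2 of the 3 values shown sit. The change also adds a hydrogen-bond donor and a hydrogen-bond acceptor that chloro lacks, and compound 3 still reaches that limit, so at this position neither feature is needed to stay there, while compound 1, with isopropoxy, remains the one compound shown that goes against the pattern.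

From the compounds shown here alone, how far compound 2 and compound 3 really lie past the limit remains unknown, so a real difference between them could still be hidden. Also open, going by these compounds, is where between hydroxy and isopropoxy the loss sets in, which a methoxy or ethoxy group at this position could help to show, and how an amine or a carboxylic acid there would behave.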